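This account rests on a few compounds, and the source may have more. Where it says the series, first, only, none or still open, it means among the compounds named here.

Measured compounds:
- compound 2, `O=C(Nc1ccc(Oc2ccnc3[nH]ccc23)c(F)c1)c1cc(-c2ccccc2)ccn1`, gives 4950 nM in a functional assay on A549 cells (Homo sapiens) for cytotoxicity, read by MTT assay, with a stated time of 72 h; on this read-out lower numbers stand for stronger inhibition and higher numbers for weaker inhibition
- compound 1, `O=C(Nc1ccc(Oc2ccnc3[nH]ccc23)cc1)c1cc(-c2ccccc2)ccn1`, gives 2920 nM in this assay

Of these two numbers, compound 2 has the higher one, but the step of a 1.7-fold higher number from compound 1 to compound 2 (0.23 log units; within the scatter) shows that the two values sit within the scatter of each other, so no real difference in potency between compound 1 and compound 2 can be claimed from them.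

Compound 3, `CCc1ccc(-c2ccnc(C(=O)Nc3ccc(Oc4ccnc5[nH]ccc45)c(F)c3)c2)cc1`, has not yet been measured. It differs from compound 2 by a single change: ethyl in place of hydrogen on an aromatic carbon. For the measured compounds named here, no measured pair shares this change. Going by the values given here, the only measured step, fluoro in place of hydrogen on an aromatic carbon, concerns a different part of the molecule and says nothing about what an ethyl group does here; it also stayed within the scatter itself. Among the compounds with values here, with that as the only guide, the expectation for compound 3 in this assay is a step of a 1.2-fold lower number from compound 2 to compound 3 (0.09 log units; within the scatter), meaning no movement beyond the scatter in either direction. Compound 3 is therefore estimated at 4000 nM, with a range from 1200 nM to 13000 nM.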

Compound 3, half-maximal inhibitory concentration: 3370 nM
For compound 3 the middle estimate is 1.2-fold (0.07 log units) above the measured one, and the stated range covers the measured number.
By their numbers in this assay, from the lowest: compounds 1, 3 and 2 (each within the scatter of the next).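

Until now, this position on the outer phenyl ring had carried only hydrogen, so compound 1 and compound 2 said nothing about what a substituent there would do. Changing phenyl to 4-ethylphenyl gives a 1.5-fold lower number from compound 2 to compound 3 (0.17 log units; within the scatter) in this assay, which shows that an ethyl group, placed para to a large group, can sit at this position without a difference that can be claimed in this read-out. No measurement on hand offers an explanation for this result, so the finding stands as an observation only.

As far as these compounds go, a single ethyl group cannot show how a methoxy group, an amine, a carboxylic acid or a longer chain such as butyl would behave at the same position, so how far this position accepts other groups remains open. Ethyl also appears here only together with the fluoro group of compound 2, which leaves open whether the same change would give a similar step on compound 1, the parent without that fluoro group.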